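Methyl for Chloro: A Small Expected Step

A few compounds are considered here, and "the series" means these few. Any claim that something is new, unique, unknown or untested is made for them only; others in the source may bear on it.

In a physicochemical assay for lipophilicity, measured as octanol-water partition (a lower number here means a more polar compound, a higher number a more lipophilic compound), compound 1 `Cc1ccc2c(c1)[n+]([O-])c(C#N)c(-c1ccco1)[n+]2[O-]` gives 0.845, compound 2 `Cc1ccc(-c2c(C#N)[n+]([O-])c3ccccc3[n+]2[O-])cc1` gives 2.09, and compound 3 `Cc1ccc(-c2c(C#N)[n+]([O-])c3cc(Cl)ccc3[n+]2[O-])cc1` gives 2.6, the highest of the three. Compound 4 `Cc1ccc(-c2c(C#N)[n+]([O-])c3cc(C)ccc3[n+]2[O-])cc1` differs from compound 3 by a single change, methyl in place of chloro on an aromatic carbon. Within the data shown here, one measured step bears on this change, though only indirectly: a number 0.51 log units higher from compound 2 to compound 3 (beyond the scatter), with chloro in place of hydrogen on an aromatic carbon. Among the measured compounds shown here, no measured step exchanges chloro for methyl. A slight fall, smaller than that modest step and not beyond the scatter, is therefore expected, with an estimated change of a number 0.15 log units lower from compound 3 to compound 4 (within the scatter). For compound 4, the estimated value is 2.45, with an expected range from 2.15 to 2.75.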

Compound 4, partition coefficient: 2.33
Estimate against measurement, compound 4: 0.12 log units above; the range from low to high includes it.
By their numbers in this assay, from the lowest: compound 1; then compounds 2, 4 and 3 (each within the scatter of the next, the first and the last beyond it).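

In this assay, methyl and chloro on this aromatic carbon cannot be told apart, with a number 0.27 log units lower from compound 3 to compound 4 (within the scatter). Methyl in place of hydrogen also stays within the scatter, with a number 0.24 log units higher from compound 2 to compound 4 (within the scatter), while chloro in place of hydrogen lies beyond it, with a number 0.51 log units higher from compound 2 to compound 3 (beyond the scatter), and the change in another place, 4-methylphenyl in place of furan-2-yl, is far larger, with a number 1.49 log units higher from compound 1 to compound 4 (beyond the scatter). Nothing available explains these steps. On these data alone, it remains open how an amine or a carboxylic acid would read on this carbon, and whether these steps would hold with furan-2-yl in the shared core.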